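Moving the Bromine Around the Benzyl Ring

The compounds below may be only part of what the source reports. "The series", "measured", "known", "first", "only" and "open" are said of these compounds alone.

Of the compounds shown here, two sharing one core have been measured in a functional assay on K562 cells (Homo sapiens) for antiproliferative activity, with a stated time of 72 h; a higher number here means a weaker inhibitor, a lower number a stronger inhibitor. Compound 1 `OC[C@H]1O[C@@H](n2cnc3c(NCc4ccccc4F)ncnc32)[C@H](O)[C@@H]1O` gives 33200 nM. Within the data shown here, compound 2 `OC[C@H]1O[C@@H](n2cnc3c(NCc4ccccc4Br)ncnc32)[C@H](O)[C@@H]1O` gives 10000 nM, the lowest of the two numbers; the single measured step, a 3.3-fold lower number from compound 1 to compound 2 (0.52 log units; beyond the scatter), is a modest gain from a bromo in place of a fluoro on an aromatic carbon. Compound 3 `OC[C@H]1O[C@@H](n2cnc3c(NCc4ccc(Br)cc4)ncnc32)[C@H](O)[C@@H]1O` has not yet been measured; it differs from compound 2 in one place: 4-bromophenyl in place of 2-bromophenyl on a saturated chain carbon bound to a nitrogen on an aromatic ring. Among the measured compounds shown here, no measured step bears directly on a change from 2-bromophenyl to 4-bromophenyl, since the only step available, a 3.3-fold lower number from compound 1 to compound 2 (0.52 log units; beyond the scatter), exchanged the halogen itself rather than the ring carbon carrying it. The expected step in this assay is therefore none beyond the scatter, no change at the digits printed from compound 2 to compound 3 (within the scatter). Compound 3 is estimated at 10000 nM, with a range from 3000 nM to 33000 nM.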

Compound 3, half-maximal inhibitory concentration: 68200 nM
For compound 3 the middle estimate is 6.8-fold (0.83 log units) below the measured one; measured number outside the range, above it.
By their numbers in this assay, from the lowest: compound 2; then compound 1; then compound 3.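

In this assay, the place of the bromine on the ring matters as well as the identity of the halogen: 4-bromophenyl in place of 2-bromophenyl gives a 6.8-fold higher number from compound 2 to compound 3 (0.83 log units; beyond the scatter) on an otherwise unchanged molecule. Bromine alone therefore does not bring the gain seen earlier, since the comparison with the fluorinated compound gives a 2.1-fold higher number from compound 1 to compound 3 (0.31 log units; beyond the scatter) and leaves the 4-bromophenyl compound as the weakest of the three, with the 2-bromophenyl compound the strongest. Nothing available here accounts for the difference between the two bromine placements.

From the compounds shown here alone, it remains open how a chloro group at either of these two places on the ring would rank against the bromo and fluoro compounds. A plain phenyl ring carrying no halogen would show whether the 2-bromophenyl group improves on the unsubstituted ring or the 4-bromophenyl group falls short of it.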